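The compounds below may be only part of what the source reports. "The series", "measured", "known", "first", "only" and "open" are said of these compounds alone.

Working notes on the series.

Among the compounds with values here, compound 1 `CN(C)C(=O)c1cc(-c2cnc(NCc3c(F)ccc4c3CCO4)c3cn[nH]c(=O)c23)n(C)n1` is the only member with a number: in an ADME assay on microsomes from liver (Homo sapiens) for metabolic stability, read by LC-MS, using NADPH, with stated times of 5 min and 30 min, tested at 1 uM (a lower number here means slower removal, a higher number faster removal of the compound), compound 1 gives 21 mL.min-1.g-1. The two other measured values are limits. Compound 2 `O=C1CCCN1c1cnc(NCc2c(F)ccc3c2CCO3)n2cnnc12` gives in this assay a limit of < 3 mL.min-1.g-1. Compound 3 `O=C(Nc1cnc(NCc2c(F)ccc3c2CCO3)n2cnnc12)c1cccnc1` likewise gives in this assay a limit of < 3 mL.min-1.g-1. The step that the two limits leave unreadable from compound 2 to compound 3 cannot be read, since both ends rest at the limit of < 3 mL.min-1.g-1 in this assay, at which 2 of the 3 values shown sit.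

Compound 4 `CC(=O)N1CCC(c2cnc(NCc3c(F)ccc4c3CCO4)c3cn[nH]c(=O)c23)CC1` differs from compound 1 in one place: 1-acetylpiperidin-4-yl in place of 3-(dimethylcarbamoyl)-1-methyl-1H-pyrazol-5-yl on an aromatic carbon. Within the data shown here, no measured step bears on this change; the only measured step, from compound 2 to compound 3, concerns another part of the structure and is itself unreadable, so the expectation for compound 4 rests on compound 1 alone. With the acyl amide retained in the entering group and no direction indicated by the data, no step beyond the scatter is expected. Compound 4 is expected to give 20 mL.min-1.g-1 in this assay, between 8 mL.min-1.g-1 and 50 mL.min-1.g-1. The step so expected is a 1.1-fold lower number from compound 1 to compound 4 (0.02 log units; within the scatter).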

Compound 4, intrinsic clearance in microsomes: 207 mL.min-1.g-1
Compound 4: middle estimate off by 10-fold (1.01 log units), on the low side; the whole stated range lies below it.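

Within the data shown here, the group on this aromatic carbon of the shared core matters in this assay: 1-acetylpiperidin-4-yl in place of 3-(dimethylcarbamoyl)-1-methyl-1H-pyrazol-5-yl gives a 9.9-fold higher number from compound 1 to compound 4 (0.99 log units; beyond the scatter), the only readable step so far. Both groups carry a carbonyl outside any aromatic ring, so that shared feature alone does not keep the number at the level of compound 1. Nothing measured in the series accounts for the size of this step.

Still open, from the compounds shown here alone, is whether the step follows the loss of the aromatic five-membered ring or the acetyl on the piperidine nitrogen. A piperidin-4-yl with a free secondary amine, a 1-methylsulfonylpiperidin-4-yl group or a plain 1-methyl-1H-pyrazol-5-yl group at this position would bear on that question.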